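The source may hold more compounds than are shown below. What is called first, only, known or untested is meant among the compounds shown, and "the series" means these compounds.

Two compounds have so far been measured in a functional assay on the whole organism for inhibition, with Rattus norvegicus as the target, read by paw edema, with stated times of 4 days, 1 h and 2 h, at a dose of 100 mg/kg by the oral route; on this read-out lower numbers stand for less inhibition and higher numbers for more inhibition at the one dose given (going by the name of the read-out):
compound 1, `CCOC(=O)C1CCN(c2nc(-c3ccccc3)nc3ccccc23)CC1`, with 70.3%;
compound 2, `Nc1nnc(C2CCN(c3nc(-c4ccccc4)nc4ccccc34)CC2)s1`, with 73%.

Compound 2 stands alongside compound 1 rather than apart from it: the step of a number 2.7 percentage points higher from compound 1 to compound 2 (within the scatter) lies within the scatter, so the two read-outs cannot be told apart. Compound 3, `O=c1[nH]nc(C2CCN(c3nc(-c4ccccc4)nc4ccccc34)CC2)s1`, has not been measured. It differs from compound 2 by a group of 6 heavy atoms (2 carbon, 2 nitrogen, 1 oxygen, 1 sulfur; one five-membered aromatic ring with 3 hetero atoms) in place of a group of 6 heavy atoms (2 carbon, 3 nitrogen, 1 sulfur; one five-membered aromatic ring with 3 hetero atoms), on a saturated ring carbon. Among the measured compounds shown here, the only measured step, a number 2.7 percentage points higher from compound 1 to compound 2 (within the scatter), exchanged one group for another at the same saturated ring carbon and produced nothing beyond the scatter; it is the single comparison that bears on the new change, and it is loose guidance, since the groups involved are not the ones exchanged here. Compound 3 is therefore expected to stay close to compound 2, with a number 3 percentage points lower from compound 2 to compound 3 (within the scatter) as the expected step and no direction beyond the scatter. The estimate for compound 3 is 70%, expected to fall between 57% and 81%.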

Compound 3, a percentage reported as inhibition, in the whole organism at one dose (the size of the read-out at that dose, not a potency): 12.7%
Beside the measured number, compound 3's estimate is 57.3 percentage points above it, outside the stated range (below it).
By their numbers in this assay, from the lowest: compound 3; then compounds 1 and 2 (each within the scatter of the next).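

In this assay, the saturated ring carbon turns out not to be indifferent to what it carries: exchanging the 5-amino-1,3,4-thiadiazol-2-yl group for the group of compound 3 gives a number 60.3 percentage points lower from compound 2 to compound 3 (beyond the scatter), although both groups hold a five-membered aromatic ring with 3 hetero atoms and the same number of heavy atoms. Against the ethoxycarbonyl group the same entering group gives a number 57.6 percentage points lower from compound 1 to compound 3 (beyond the scatter), so the two groups that lie within the scatter of each other both stand well clear of it. Nothing available here explains this difference.

The compounds shown leave open how other groups on this carbon would read out, such as a carboxylic acid, a primary amide or a 5-methyl-1,3,4-thiadiazol-2-yl group. They also leave open whether the gap would persist at doses other than the single one given.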